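Methylation of the Fused Core Nitrogen in Compound 1

The source may report more compounds than this note shows. Statements on the series, on what has been measured and on what is new or still open speak of the compounds shown alone.

Measured compounds:
compound 1 `O=C(Nc1ccc(Oc2ccnc3[nH]ccc23)cc1)c1nn(-c2ccc(Br)cc2)ccc1=O`, 7890 nM
compound 2 `O=C(Nc1ccc(Oc2ccnc3[nH]ccc23)cc1)c1nn(-c2ccccc2)ccc1=O`, 15600 nM
compound 3 `O=C(Nc1ccc(Oc2ccnc3[nH]ccc23)cc1)c1nn(-c2ccc(Cl)c(C(F)(F)F)c2)ccc1=O`, 6270 nM

In a functional assay on MCF7 cells (Homo sapiens) for cytotoxicity, read by MTT assay, with a stated time of 72 h (on this read-out higher numbers stand for weaker inhibition and lower numbers for stronger inhibition), compound 1 gives 7890 nM, the second highest of the three numbers: compound 3 lies nearest to it, as a 1.3-fold lower number from compound 1 to compound 3 (0.10 log units; within the scatter) shows, and compound 2 furthest, as a 2.0-fold higher number from compound 1 to compound 2 (0.30 log units; within the scatter) shows. Compound 4 `Cn1ccc2c(Oc3ccc(NC(=O)c4nn(-c5ccc(Br)cc5)ccc4=O)cc3)ccnc21` differs from compound 1 by methyl in place of hydrogen on an aromatic nitrogen, on an aromatic nitrogen of a five-membered aromatic ring within the fused system of two rings. Going by the values given here, none of the measured steps touches this place; all of them, including a 2.5-fold lower number from compound 2 to compound 3 (0.40 log units; beyond the scatter), alter the aryl group on the other aromatic nitrogen. The data therefore give no guidance beyond the shared core, and compound 4 is expected to show no step beyond the scatter, estimated at 9000 nM with a range from 3000 nM to 30000 nM, meaning a 1.1-fold higher number from compound 1 to compound 4 (0.06 log units; within the scatter).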

Compound 4, half-maximal inhibitory concentration: 16300 nM
Compound 4: the middle estimate sits 1.8-fold (0.26 log units) below what was measured, within the range that was stated.
By their numbers in this assay, from the lowest: compounds 3, 1, 2 and 4 (each within the scatter of the next, the first and the last beyond it).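

In this assay, methyl in place of hydrogen on the aromatic nitrogen of the five-membered aromatic ring gives a 2.1-fold higher number from compound 1 to compound 4 (0.32 log units; beyond the scatter) and so weaker inhibition. This shows that the position responds to even this single added carbon, whereas every earlier step altered the aryl group on the other aromatic nitrogen. Nothing measured here explains the step.

Going by these compounds, whether an ethyl or a 2-hydroxyethyl group on this nitrogen would behave like methyl remains open. So does whether methyl would give a similar step with the phenyl group of compound 2 or the 4-chloro-3-(trifluoromethyl)phenyl group of compound 3.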